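The compounds below may be only part of what the source reports. "The series", "measured", "known", "first", "only" and "open" are said of these compounds alone.

Working notes on a series of aryl acetic acids assessed in an assay on CHO cells for displacement of a labelled ligand from prostaglandin D2 receptor 2 (Homo sapiens), read by scintillation counting; on this read-out lower numbers stand for stronger inhibition and higher numbers for weaker inhibition. Compound 1 `Cc1ccc(S(=O)(=O)N2CCN(C)CC2)cc1C#Cc1cc(Cl)ccc1OCC(=O)O` gives 21 nM in this assay, the lowest of the two numbers recorded. Compound 2 `O=C(O)COc1ccc(Cl)cc1C#Cc1ccc(Cl)s1` differs from compound 1 in several places. In this assay compound 2 gives 183 nM, a higher number that lies beyond the scatter; with two sites of change no single step can be read from this pair.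

Compound 3 `Cc1ccc(S(=O)(=O)N2CCOCC2)cc1C#Cc1cc(Cl)ccc1OCC(=O)O` has not yet been measured. It differs from compound 1 in one place: morpholin-4-yl in place of 4-methylpiperazin-1-yl on a sulfonyl sulfur. Going by the values given here, no measured pair in the set shows the effect of this change, so the size of the step cannot be taken from the data. A small step is expected, with the number for compound 3 estimated at 30 nM, plausibly between 10 nM and 90 nM; the expected change from compound 1 to compound 3 is a 1.4-fold higher number from compound 1 to compound 3 (0.15 log units; within the scatter), which would sit within the usual scatter.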

Compound 3, inhibition constant: 3.6 nM
Compound 3: middle estimate off by 8.3-fold (0.92 log units), on the high side; measured number outside the range, below it.
By their numbers in this assay, from the lowest: compound 3; then compound 1; then compound 2.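

Going by these compounds alone, at the sulfonyl sulfur, whose other neighbour is an aromatic carbon, the choice of ring proves to matter in this assay: morpholin-4-yl in place of 4-methylpiperazin-1-yl gives a 5.8-fold lower number from compound 1 to compound 3 (0.77 log units; beyond the scatter) and is the first single-place step. Both groups are six-membered non-aromatic rings with 2 hetero atoms and have the same donor and acceptor counts, so a change that leaves those counts untouched is still enough to move the number beyond the scatter. Nothing available on these compounds accounts for the step.

Going by these compounds, whether the step follows the ring oxygen or the absence of the methyl-bearing ring nitrogen remains open. A piperidin-1-yl or dimethylamino group on the same sulfonyl sulfur would help separate the two.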